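Furan swap on the 4-fluorophenyl compound

This account rests on a few compounds, and the source may have more. Where it says the series, first, only, none or still open, it means among the compounds named here.

- Compound 1 `Nc1ncnn2c([C@@H]3O[C@H](CO)[C@@H](O)[C@H]3O)cc(C#Cc3cccs3)c12`: 65500 nM
- Compound 2 `Nc1ncnn2c([C@@H]3O[C@H](CO)[C@@H](O)[C@H]3O)cc(-c3ccc(F)cc3)c12`: 42500 nM

In a functional assay on HCT-116 cells (Homo sapiens) for antiproliferative activity, with a stated time of 72 h (on this read-out higher numbers stand for weaker inhibition and lower numbers for stronger inhibition), compound 2 stands level with compound 1. Compound 3 `Nc1ncnn2c([C@@H]3O[C@H](CO)[C@@H](O)[C@H]3O)cc(-c3ccoc3)c12` has furan-3-yl in place of 4-fluorophenyl on an aromatic carbon. Among the measured compounds shown here, the only measured step that bears on this change, a 1.5-fold lower number from compound 1 to compound 2 (0.19 log units; within the scatter), exchanges the group at the same place and stays within the scatter. With this single step as a guide, no change beyond the scatter is expected, and the expected step is a 1.0-fold lower number from compound 2 to compound 3 (0.01 log units; within the scatter). The estimate for compound 3 is 42000 nM, with an expected range of 14000 nM to 95000 nM.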

Compound 3, half-maximal inhibitory concentration: 1400 nM
The estimate for compound 3 lay 30-fold (1.48 log units) above the measured number; measured number outside the range, below it.
By their numbers in this assay, from the lowest: compound 3; then compounds 2 and 1 (each within the scatter of the next).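

In this assay, the group on this aromatic carbon can shift the number well beyond the scatter: furan-3-yl in place of 4-fluorophenyl gives a 30-fold lower number from compound 2 to compound 3 (1.48 log units; beyond the scatter), and furan-3-yl in place of 2-(thiophen-2-yl)ethynyl gives a 47-fold lower number from compound 1 to compound 3 (1.67 log units; beyond the scatter). The two earlier groups stood level and gave no sign that this position responds to its substituent. No measurement at hand accounts for the gain.

Open, on these data alone, is whether the gain is specific to furan-3-yl or extends to other small rings. Furan-2-yl, thiophen-3-yl or pyrrol-3-yl at this place would test that.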